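The source may report more compounds than this note shows. Statements on the series, on what has been measured and on what is new or still open speak of the compounds shown alone.

Measured in a functional assay on Z-138 cells (Homo sapiens) for inhibition, read by luminescence and CellTiter-Glo, with a stated time of 72 h; a higher number here means a weaker inhibitor, a lower number a stronger inhibitor:
- compound 1 `C=CC(=O)Nc1ccc(Cn2nc(-c3ccc(Oc4ccccc4)cc3)cc2C(=O)OCC)cc1` gives 12500 nM.
- compound 2 `C/C=C/C(=O)Nc1ccc(Cn2nc(-c3ccc(Oc4ccccc4)cc3)cc2C(=O)OCC)cc1` gives > 60000 nM; this is the limit of > 60000 nM in this assay, at which 1 of the 3 values shown sits, not a measured number.
- compound 3 `C/C=C/C(=O)Nc1cccc(Cn2nc(-c3ccc(Oc4ccccc4)cc3)cc2C(=O)OCC)c1` gives 8900 nM.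

Compound 3 has the lower of the two numbers shown, but its gap to compound 1, a 1.4-fold lower number from compound 1 to compound 3 (0.15 log units; within the scatter), lies within the scatter, so the two cannot be ranked. Compound 4 `CCOC(=O)c1cc(-c2ccc(Oc3ccccc3)cc2)nn1Cc1ccc(NC(=O)CCl)cc1` differs from compound 3 in one place: 4-(((chloromethyl)carbonyl)amino)phenyl in place of 3-(((prop-1-en-1-yl)carbonyl)amino)phenyl on a saturated chain carbon bound to an aromatic nitrogen. For the measured compounds named here, two measured steps bear on this. The step of an at least 6.7-fold lower number from compound 2 to compound 3 (0.82 log units; beyond the scatter) compares the same prop-1-en-1-yl carbonyl amide on the 4- and 3-substituted phenyl; compound 4 returns to the 4-substituted phenyl, which on its own points to a higher number. The step of an at least 4.8-fold higher number from compound 1 to compound 2 (0.68 log units; beyond the scatter) shows that on the 4-substituted phenyl the group on the carbonyl carbon matters strongly, vinyl giving a number and prop-1-en-1-yl only a limit. Chloromethyl on the carbonyl carbon has no measured precedent here, so the nearest comparison is compound 1 at 12500 nM. Compound 4 is therefore expected to land near compound 1, estimated at 15000 nM with a range from 4000 nM to 60000 nM. This estimate means an expected step of a 1.7-fold higher number from compound 3 to compound 4 (0.23 log units; within the scatter), with a real chance that only a limit is reported.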

Compound 4, half-maximal inhibitory concentration: 400 nM
Compound 4: the middle estimate sits 38-fold (1.57 log units) above what was measured; the whole stated range lies above it.
By their numbers in this assay, from the lowest: compound 4; then compounds 3 and 1 (each within the scatter of the next). At a limit, above all of these: compound 2.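

For the compounds shown here, with the amide kept where compound 1 has it, the group on the carbonyl carbon turns out to matter far more than the earlier compounds showed: chloromethyl in place of vinyl gives a 31-fold lower number from compound 1 to compound 4 (1.49 log units; beyond the scatter) in this assay. Chloromethyl in place of prop-1-en-1-yl gives an at least 150-fold lower number from compound 2 to compound 4 (2.17 log units; beyond the scatter), and that step starts from a limit for compound 2, not a number: the limit of > 60000 nM in this assay, at which 1 of the 4 values shown sits. The placement that favoured compound 3 over compound 2 is also no barrier to a low number, as the 4-(((chloromethyl)carbonyl)amino)phenyl group gives a 22-fold lower number from compound 3 to compound 4 (1.35 log units; beyond the scatter).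

Going by these compounds, it remains open whether chloromethyl would do as well with the amide in the place it holds in compound 3. A plain methyl or a bromomethyl on the carbonyl carbon would show how much of this step depends on the chlorine.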